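The source may hold more compounds than are shown below. What is called first, only, known or untested is meant among the compounds shown, and "the series" means these compounds.

Compound 1 `CCc1ccccc1N(Cc1nnc(Cc2ccc(Cl)cc2)o1)S(=O)(=O)c1ccc(C)cc1` is the starting point of this short series: in a functional assay on CHO cells for antagonist activity at prostaglandin E2 receptor EP1 subtype (Homo sapiens), read by FLIPR and calcium flux (a higher number here means a weaker inhibitor, a lower number a stronger inhibitor), compound 1 gives 316 nM. Compound 2 `CCc1ccccc1N(Cc1nnc(COc2ccc(OC)cc2)o1)S(=O)(=O)c1ccc(C)cc1` keeps the shared core and the sulfonyl part and differs only at the group on the saturated chain carbon bound to an aromatic carbon, and in this assay compound 2 gives 126 nM. The change from compound 1 to compound 2 brought a 2.5-fold lower number from compound 1 to compound 2 (0.40 log units; beyond the scatter). Among the measured compounds shown here, of the two numbers known in this assay, compound 2 therefore holds the lowest, with compound 1 as its only neighbour.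

Compound 3 `CCc1ccccc1N(Cc1nnc(CNc2ccc(OC)cc2)o1)S(=O)(=O)c1ccc(C)cc1` is not yet measured. Its difference from compound 2 is (4-methoxyphenyl)amino in place of 4-methoxyphenoxy on a saturated chain carbon bound to an aromatic carbon. For the measured compounds named here, the only measured step, a 2.5-fold lower number from compound 1 to compound 2 (0.40 log units; beyond the scatter), concerns the same position but exchanges a different pair of groups, so it shows that this position can move the number by a modest amount, without telling which way the present exchange will go. The expectation for compound 3 is therefore a step of a 1.3-fold higher number from compound 2 to compound 3 (0.10 log units; within the scatter) in this assay, within or close to the scatter, giving an estimate of 160 nM, between 55 nM and 470 nM.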

Compound 3, inhibition constant: 794 nM
Compound 3: the middle estimate sits 5.0-fold (0.70 log units) below what was measured; measured number outside the range, above it.
By their numbers in this assay, from the lowest: compound 2; then compound 1; then compound 3.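

In this assay, the entering (4-methoxyphenyl)amino differs from the leaving 4-methoxyphenoxy by a nitrogen in place of an oxygen and by its one hydrogen-bond donor, and this exchange gives a 6.3-fold higher number from compound 2 to compound 3 (0.80 log units; beyond the scatter) on the same saturated chain carbon. The position therefore responds strongly to a change confined to the atom linking the 4-methoxyphenyl ring, a sensitivity that the earlier exchange of two quite different groups could not isolate. The comparison with the 4-chlorophenyl group gives a 2.5-fold higher number from compound 1 to compound 3 (0.40 log units; beyond the scatter) as well, so groups at this position can now be seen to fall on either side of compound 1, and no information at hand accounts for this difference.

The compounds shown leave open whether a thioether sulfur, or an amine nitrogen carrying a methyl group and so no hydrogen-bond donor, would behave like the ether link of compound 2 or the amine link of compound 3. They also leave open whether the gap between these two links would persist with a chloro group in place of the methoxy group on the ring.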